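Piperidinyl in place of cyclohexylamino on a weakly cytotoxic benzamide

The source may report more compounds than this note shows. Statements on the series, on what has been measured and on what is new or still open speak of the compounds shown alone.

Measured compounds:
compound 1, `O=C(Nc1cc(C(F)(F)F)ccc1NC1CCCCC1)c1ccccc1`, "not active" (no number reported) in a functional assay on NALM-6 cells (Homo sapiens) for cytotoxicity, read by MTT assay, with a stated time of 48 h; a higher number here means a weaker inhibitor, a lower number a stronger inhibitor
compound 2, `O=C(Nc1cc(C(F)(F)F)ccc1NC1CCCCC1)c1cccnc1`, 52300 nM
compound 3, `O=C(Nc1cc(C(F)(F)F)ccc1Nc1ccc(Br)cc1)c1cccnc1Cl`, 35700 nM

Of the compounds shown here, three have been tested for cytotoxicity. In this assay compound 1 is reported as "not active" (no number reported), so no number stands for it. Compound 2 carries a pyridine-derived amide and gives 52300 nM in this assay. Compound 3, with a chloro-substituted pyridine amide and a bromophenylamino group on the core, gives 35700 nM in this assay. The values of compound 2 and compound 3 lie within the usual scatter of each other, so nothing is said here about their order. Compound 1 stands apart only in that it yielded no number at all.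

Compound 4, `O=C(Nc1cc(C(F)(F)F)ccc1N1CCCCC1)c1ccccc1`, has not yet been measured. The change from compound 1 is piperidin-1-yl in place of cyclohexylamino on an aromatic carbon. Nothing measured connects compound 1 to compound 4 by a single step, so the size of the step in this assay is not known; the expectation is a step of no more than the scatter, in either direction. Compound 4 is therefore expected to give roughly 60000 nM in this assay, within a range from 20000 nM to 200000 nM, with a considerable chance that only a limit is reported again.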

Compound 4, half-maximal inhibitory concentration: "not active" (no number reported)
Compound 4 has no reported number here; the estimate stays without a comparison.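

In this assay compound 1 is reported as "not active" (no number reported) and compound 4 as "not active" (no number reported) so no step can be read between them for piperidin-1-yl in place of cyclohexylamino. The compounds shown leave open whether this exchange alters cytotoxicity at all. No further evidence bears on this result.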